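The source may hold more compounds than are shown below. What is called first, only, known or untested is meant among the compounds shown, and "the series" means these compounds.

In an ADME assay on Vero cells (Chlorocebus sabaeus) for cytotoxicity, read by MTT assay, with a stated time of 72 h (on this read-out lower numbers stand for higher toxicity in this test and higher numbers for lower toxicity in this test), compound 1 `CCOC(=O)c1c(-c2ccc(OC)cc2)oc2ccc(OCCCCCCN3C(=O)/C(=N\OC)c4ccccc43)cc12` gives 32 ug/mL and compound 2 `CCOC(=O)c1c(-c2ccc(OC)cc2)oc2ccc(OCCCCCCN3C(=O)/C(=N\NC(N)=S)c4ccccc43)cc12` gives 8 ug/mL, so compound 2 holds the lower of the two numbers. The next entry is compound 3 `CCO/N=C1\C(=O)N(CCCCCCOc2ccc3oc(-c4ccc(OC)cc4)c(C(=O)OCC)c3c2)c2ccccc21`, where the change is a group of 3 heavy atoms (2 carbon, 1 oxygen; no ring) in place of a group of 4 heavy atoms (1 carbon, 2 nitrogen, 1 sulfur; no ring), on a double-bonded nitrogen; the entering group is ethoxy. Going by the values given here, only one measured step bears on this: a 4.0-fold lower number from compound 1 to compound 2 (0.60 log units; beyond the scatter), a modest step beyond the scatter. That step brought in the same group that now leaves, at the same place. Among the compounds with values here, no measured compound carries ethoxy itself, so the group on compound 1 serves only as the nearest available comparison. A reversal of similar size is therefore expected in this assay, towards a higher number. The expected step is a 3.5-fold higher number from compound 2 to compound 3 (0.54 log units; beyond the scatter). The estimate for compound 3 is 28 ug/mL, with an expected range of 12 ug/mL to 64 ug/mL.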

Compound 3, half-maximal cytotoxic concentration: 16 ug/mL
Estimate against measurement, compound 3: 1.8-fold (0.24 log units) above; low and high end bracket the measured number.
By their numbers in this assay, from the lowest: compounds 2, 3 and 1 (each within the scatter of the next, the first and the last beyond it).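

At this place on the double-bonded nitrogen, ethoxy in place of the larger sulfur-bearing group gives a 2.0-fold higher number from compound 2 to compound 3 (0.30 log units; within the scatter) in this assay. Lengthening the oxygen-bound chain, with methyl in place of hydrogen on a saturated chain carbon bound to an oxygen on an unsaturated carbon, gives a 2.0-fold lower number from compound 1 to compound 3 (0.30 log units; within the scatter) in the same test. Compound 3 therefore cannot be separated from either neighbour, and only the gap shown by a 4.0-fold lower number from compound 1 to compound 2 (0.60 log units; beyond the scatter) remains resolved. No measurement on hand accounts for these numbers.

The compounds shown leave open how a longer chain such as butoxy, or a hydroxyl group, would read at this place in this assay. They also leave open whether an amine or a carboxylic acid here would stay within the scatter of compound 3.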